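A few compounds are considered here, and "the series" means these few. Any claim that something is new, unique, unknown or untested is made for them only; others in the source may bear on it.

Measured compounds in this set:

- compound 1, `CCN(CC)CCNC(=O)c1ccc(C(CC)(CC)c2ccc(OCS(=O)(=O)c3ccccc3)c(C)c2)n1CC`: 4680 nM
- compound 2, `CCn1c(C(=O)NC(C)(C)CO)ccc1C(CC)(CC)c1ccc(OCS(=O)(=O)c2ccccc2)c(C)c1`: 20700 nM
- compound 3, `CCn1c(C(=O)N[C@@H](CO)C(C)C)ccc1C(CC)(CC)c1ccc(OCS(=O)(=O)c2ccccc2)c(C)c1`: 18800 nM

In a functional assay on MCF7 cells (Homo sapiens) for antiproliferative activity, read by MTT assay, with a stated time of 24 h (on this read-out lower numbers stand for stronger inhibition and higher numbers for weaker inhibition), compound 2 stands with the highest number of the three. Its nearest neighbour is compound 3, with a 1.1-fold lower number from compound 2 to compound 3 (0.04 log units; within the scatter), so the two cannot be ordered. The furthest is compound 1, which gives 4680 nM; the step to compound 2 is a 4.4-fold higher number from compound 1 to compound 2 (0.65 log units; beyond the scatter), and the parallel step to compound 3 is a 4.0-fold higher number from compound 1 to compound 3 (0.60 log units; beyond the scatter).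

Compound 4, `CCn1c(C(=O)N[C@@H](C(=O)O)C(C)C)ccc1C(CC)(CC)c1ccc(OCS(=O)(=O)c2ccccc2)c(C)c1`, has not been measured. Its difference from compound 2 is 1-carboxy-2-methylpropyl in place of 1-(hydroxymethyl)-1-methylethyl on an amide-type nitrogen.

For the measured compounds named here, the step that bears most directly on this is the one from compound 2 to compound 3, which exchanged one branched hydroxymethyl-bearing group for another and stayed within the scatter. Going by the values given here, no measured step exchanges a hydroxymethyl for a carboxy group, so that part of the change is uncharted. With a carboxy group in place, the expectation is a step in this assay no larger than modest, most likely towards a higher number, and possibly none beyond the scatter: a 1.3-fold higher number from compound 2 to compound 4 (0.10 log units; within the scatter). Compound 4 is therefore estimated at 26000 nM, with a range of 8000 nM to 80000 nM.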

Compound 4, half-maximal inhibitory concentration: 44700 nM
For compound 4 the middle estimate is 1.7-fold (0.24 log units) below the measured one, and the stated range covers the measured number.
By their numbers in this assay, from the lowest: compound 1; then compounds 3 and 2 (each within the scatter of the next); then compound 4.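

In this assay carboxy in place of hydroxymethyl on the saturated chain carbon bound to the amide-type nitrogen gives a 2.4-fold higher number from compound 3 to compound 4 (0.38 log units; beyond the scatter) as a step beyond the scatter, whereas exchanging one hydroxymethyl-bearing group for another had stayed within it. The comparison with the other hydroxymethyl-bearing compound points the same way, with a 2.2-fold higher number from compound 2 to compound 4 (0.33 log units; beyond the scatter) also beyond the scatter, and a 9.6-fold higher number from compound 1 to compound 4 (0.98 log units; beyond the scatter) widens the span at this position, leaving the 2-(diethylamino)ethyl group of compound 1 with the lowest number of the four. Nothing available accounts for these differences.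

On these data alone, a methyl ester or a primary carboxamide in place of the carboxy group remains open, as does whether a 2-(dimethylamino)ethyl chain would keep the lower number seen with compound 1. As far as these compounds go, the opposite configuration at the defined stereocentre of compound 4 also remains open.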